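Second Methyl Group on the Aryl Ketone of Compound 3

The compounds below may be only part of what the source reports. "The series", "measured", "known", "first", "only" and "open" are said of these compounds alone.

In a functional assay on MDA-MB-231 cells (Homo sapiens) for antiproliferative activity, read by MTT assay, with a stated time of 24 h (a higher number here means a weaker inhibitor, a lower number a stronger inhibitor), compound 3 `COc1ccc(-c2cc(/C=C/C(=O)c3ccc(C)cc3)nc3cc(-c4ccccc4)nn23)cc1OC` gives 19800 nM, the second highest of the three numbers recorded. Compound 1 `COc1ccc(-c2cc(C(=O)/C=C/c3ccccc3)nc3cc(-c4ccccc4)nn23)cc1OC` gives 23300 nM, and the step of a 1.2-fold lower number from compound 1 to compound 3 (0.07 log units; within the scatter) stays within the scatter. Compound 2 `COc1ccc(-c2cc(/C=C/C(=O)c3cc(OC)c(OC)c(OC)c3)nc3cc(-c4ccccc4)nn23)cc1OC` gives 4700 nM, and the step of a 4.2-fold higher number from compound 2 to compound 3 (0.62 log units; beyond the scatter) lies beyond it. Compound 4 `COc1ccc(-c2cc(/C=C/C(=O)c3ccc(C)c(C)c3)nc3cc(-c4ccccc4)nn23)cc1OC` differs from compound 3 by methyl in place of hydrogen on an aromatic carbon. Within the data shown here, no measured step adds a single methyl: the one step beyond the scatter exchanges a whole trimethoxyphenyl group, and the other, a change elsewhere in the molecule, stays within the scatter. A second methyl is therefore expected to move the number only a little, a step of a 1.3-fold lower number from compound 3 to compound 4 (0.12 log units; within the scatter). Compound 4 is expected to give 15000 nM, within 6000 nM to 40000 nM.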

Compound 4, half-maximal inhibitory concentration: 11500 nM
For compound 4 the middle estimate is 1.3-fold (0.12 log units) above the measured one; measured number inside the range.
By their numbers in this assay, from the lowest: compound 2; then compounds 4, 3 and 1 (each within the scatter of the next, the first and the last beyond it).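

In this assay, this added methyl on the six-membered aromatic ring, ortho to a methyl group, gives a 1.7-fold lower number from compound 3 to compound 4 (0.24 log units; within the scatter), so on its own this single change cannot be told apart from no change. Even so, it is the 3,4-dimethylphenyl compound that first separates from the other ketone arrangement, with a 2.0-fold lower number from compound 1 to compound 4 (0.31 log units; beyond the scatter), while the trimethoxyphenyl group still holds its edge, with a 2.4-fold higher number from compound 2 to compound 4 (0.39 log units; beyond the scatter). Nothing available gives a reason for these steps. On these data alone, what a fluorine or an amine in place of this methyl would give stays open.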